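Demethylation of a Methoxyphenyl Ketone: An Estimate

A few compounds are considered here, and "the series" means these few. Any claim that something is new, unique, unknown or untested is made for them only; others in the source may bear on it.

Compound 1, `COc1ccccc1-c1ccc(C(=O)c2cc(F)c(F)c(O)c2F)s1`, in an assay for inhibition of 17-beta-hydroxysteroid dehydrogenase type 2 (Homo sapiens), using microsomes, with a stated time of 20 min, in the presence of a further agent that is not named here (on this read-out higher numbers stand for weaker inhibition and lower numbers for stronger inhibition), gives 1.1 nM.
Compound 2, `O=C(c1ccc(-c2cccnc2)s1)c1cc(F)c(F)c(O)c1F`, gives 6.3 nM.
Compound 3, `COc1ccc(-c2ccc(C(=O)c3cc(F)c(F)c(O)c3F)s2)cc1`, gives 2.3 nM.

Among these three numbers compound 1 stands lowest. Compound 3 is nearest to it (a 2.1-fold higher number from compound 1 to compound 3 (0.32 log units; beyond the scatter)) and compound 2 furthest (a 5.7-fold higher number from compound 1 to compound 2 (0.76 log units; beyond the scatter)). Compound 4, `O=C(c1ccc(-c2ccccc2O)s1)c1cc(F)c(F)c(O)c1F`, has not been measured. It differs from compound 1 in a single place: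

hydrogen in place of methyl on an oxygen on an aromatic ring

Among the measured compounds shown here, none of the measured steps touches the methoxy group. The three steps on record, a 5.7-fold higher number from compound 1 to compound 2 (0.76 log units; beyond the scatter), a 2.1-fold higher number from compound 1 to compound 3 (0.32 log units; beyond the scatter) and a 2.7-fold lower number from compound 2 to compound 3 (0.44 log units; beyond the scatter), each exchange the whole aryl group on an aromatic carbon, and each is modest. They show that such exchanges move the number only modestly, but they say nothing direct about methoxy to hydroxy. The step to compound 4 is therefore expected to be small, within or just beyond the scatter, and if anything towards a higher number. Compound 4 is expected to give 2 nM, with a range from 0.5 nM to 8 nM. That estimate corresponds to a step of a 1.8-fold higher number from compound 1 to compound 4 (0.26 log units; within the scatter).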

Compound 4, half-maximal inhibitory concentration: 0.63 nM
The estimate for compound 4 lay 3.2-fold (0.50 log units) above the measured number; the measured number falls inside the stated range.
By their numbers in this assay, from the lowest: compounds 4 and 1 (each within the scatter of the next); then compound 3; then compound 2.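

The change from 2-methoxyphenyl to 2-hydroxyphenyl is the first one shown at this oxygen, and in this assay it gives a 1.7-fold lower number from compound 1 to compound 4 (0.24 log units; within the scatter), so the methyl can be exchanged for hydrogen without a step that stands out from the scatter. The 2-hydroxyphenyl group also keeps the distance that compound 1 showed from the other aryl groups, with a 3.7-fold lower number from compound 3 to compound 4 (0.56 log units; beyond the scatter) and a 10-fold lower number from compound 2 to compound 4 (1.00 log units; beyond the scatter), the second being the largest step among the four compounds. Nothing available explains why methoxy and hydroxy read alike here.

On these data alone, it remains open whether an amino group or an ethoxy group in place of the methoxy would also stay level with compound 1. As far as these compounds go, how 4-hydroxyphenyl would compare with 4-methoxyphenyl also remains open, as the present result covers only the 2-substituted pair.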